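Fluoro in place of benzamido: working notes

The compounds below may be only part of what the source reports. "The series", "measured", "known", "first", "only" and "open" are said of these compounds alone.

Of the compounds shown here, three have been read in an ADME assay on L132 cells (Homo sapiens) for cytotoxicity, read by MTT assay, with a stated time of 72 h; on this read-out higher numbers stand for weaker inhibition and lower numbers for stronger inhibition. Compound 1 (`COc1ccc(C2=C(c3cc(OC)c(OC)c(OC)c3)C(=O)C(OC(C)=O)C2)cc1`) gives > 100 ug/mL as a limit of the assay and not a number. Compound 2 (`COc1ccc(C2=C(c3cc(OC)c(OC)c(OC)c3)C(=O)C(O)C2)cc1NC(=O)c1ccccc1`) gives > 100 ug/mL as a limit too. Compound 3 (`COC(=O)c1cc(C2=C(c3cc(OC)c(OC)c(OC)c3)C(=O)CC2O[SiH2]C(C)(C)C)ccc1OC`) gives > 100 ug/mL as a limit as well. Compound 2 stands with the other two at the limit of > 100 ug/mL in this assay, at which 3 of the 3 values shown sit, and so has no number of its own.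

Compound 4 (`COc1ccc(C2=C(c3cc(OC)c(OC)c(OC)c3)C(=O)C(O)C2)cc1F`) departs from compound 2 by fluoro in place of benzamido on an aromatic carbon and carries fluoro in place of benzamido on an aromatic carbon, ortho to a methoxy group. The only reference point for it is compound 2 with its limit of > 100 ug/mL in this assay as the starting mark. The estimated step is a number no higher from compound 2 to compound 4 (the limit leaves the size open) with no change beyond the scatter expected and any shift going toward stronger inhibition. For compound 4 the estimate is 100 ug/mL with an expected range from 30 ug/mL to 200 ug/mL and a report at the limit remains likely.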

Compound 4, half-maximal inhibitory concentration: < 1 ug/mL
Compound 4 gave a limit, no number; the forecaster's own chance of this, stated with the estimate: 70%; middle value at least 100-fold (2.00 log units) away from the limit.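

In this assay, fluoro in place of benzamido on an aromatic carbon, ortho to a methoxy group, gives an at least 100-fold lower number from compound 2 to compound 4 (2.00 log units; beyond the scatter). Compound 4 reads < 1 ug/mL, which is a limit of the assay and not a number, and it is the only compound shown that has left the upper limit: the limit of < 1 ug/mL in this assay, at which 1 of the 4 values shown sits.
The earlier compounds shown here all sat at one limit and could not show whether any change moves this read-out, whereas this single change at this one aromatic carbon takes the value from one limit to the other.

On these data alone, the true size of the step stays open, since both of its ends are limits, and so does whether fluoro itself or the loss of benzamido carries it. An amine or a chloro on the same aromatic carbon would separate these two readings.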